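Removing a chloro group: solubility of a salicylanilide series

This account rests on a few compounds, and the source may have more. Where it says the series, first, only, none or still open, it means among the compounds named here.

The measured compounds:
compound 1, `O=C(Nc1ccc(F)c(Cl)c1)c1cc(Cl)ccc1O`, 2.4 ug/mL
compound 2, `O=C(Nc1ccc(F)cc1)c1cc(Cl)ccc1O`, 1.6 ug/mL
compound 3, `O=C(Nc1ccc(Cl)cc1Cl)c1cc(Cl)ccc1O`, a limit of the assay only

In a physicochemical assay for solubility (on this read-out higher numbers stand for higher solubility and lower numbers for lower solubility), compound 1 gives 2.4 ug/mL. Compound 2, which carries the change (hydrogen in place of chloro on an aromatic carbon), gives 1.6 ug/mL in this assay. The step of a 1.5-fold lower number from compound 1 to compound 2 (0.18 log units; within the scatter) is within the scatter, so the two values are treated as the same.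

For compound 3 this assay reports only a limit, < 1 ug/mL, at which one of the three values sits (the limit of < 1 ug/mL in this assay, at which 1 of the 3 values shown sits). The difference between the core of compound 1 and the core of compound 3 is not broken down here.

Compound 4, `O=C(Nc1ccc(Cl)cc1)c1cc(Cl)ccc1O`, has not yet been measured in this assay. It differs from compound 3 by hydrogen in place of chloro on an aromatic carbon. For the measured compounds named here, this is the same kind of change as the one from compound 1 to compound 2, but the surroundings differ: in compound 2 the carbon that takes the hydrogen is ortho to a fluoro group and meta to a large group, whereas in compound 4 it is ortho to a large group and meta to a chloro group.

Going by the values given here, the only measured example of this kind of change, a 1.5-fold lower number from compound 1 to compound 2 (0.18 log units; within the scatter), stayed within the scatter. On that basis the step from compound 3 to compound 4 is expected to be small, an at least 1.3-fold higher number from compound 3 to compound 4 (0.11 log units; that floor lies within the scatter), though since compound 3 gives only a limit the starting point itself is uncertain. Compound 4 is therefore estimated at 1.3 ug/mL in this assay, with a range from 0.6 ug/mL to 2.8 ug/mL.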

Compound 4, solubility: < 1 ug/mL
Compound 4 gave a limit, no number (the forecaster's own chance of this, stated with the estimate: 35%); at least 1.3-fold (0.11 log units) between middle value and limit.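

Both compound 3 and compound 4 stand at a limit in this assay, not at a number, so the step between them cannot be read and the removal of the chloro group on this core has no measurable size: the limit of < 1 ug/mL in this assay, at which 2 of the 4 values shown sit.

For the compounds shown here, the one readable step that reaches compound 4 belongs to a different change, chloro in place of fluoro on an aromatic carbon, and it stands at an at least 1.6-fold lower number from compound 2 to compound 4 (0.20 log units; that floor lies within the scatter). The earlier example of hydrogen in place of chloro on an aromatic carbon, a 1.5-fold lower number from compound 1 to compound 2 (0.18 log units; within the scatter), therefore remains the only readable case, and the result neither confirms nor contradicts that it carries over from the core of compound 1 to the core of compound 3.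

Going by these compounds, it remains open how large the change from chloro to hydrogen would be on a second core where both partners give numbers in this assay. The groups that vary among the compounds shown are only chloro, fluoro and hydrogen, so it also remains open how an amine or a carboxylic acid on the same aromatic ring would read in this assay.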